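A New Ring on the Carbonyl of Compound 3

The source may report more compounds than this note shows. Statements on the series, on what has been measured and on what is new or still open speak of the compounds shown alone.

Four compounds share one core and differ in the group on a carbonyl carbon. Going by the values given here, in an ADME assay on microsomes from liver (Homo sapiens) for metabolic stability, with a stated time of 10 min (on this read-out lower numbers stand for a less stable compound and higher numbers for a more stable compound), compound 3 `O=C([C@H]1CC[C@H](CO)CC1)N1CC[C@](c2ccc(C(F)(C(F)(F)F)C(F)(F)F)cc2)(S(=O)(=O)c2ccc(F)cc2)C1` gives 75% as the only single number available, so it has no single figure to be ranked against. Compound 2 `O=C(O)C1CCC(O)(C(=O)N2CC[C@](c3ccc(C(F)(C(F)(F)F)C(F)(F)F)cc3)(S(=O)(=O)c3ccc(F)cc3)C2)CC1` has two entries, 100%; 95% (2 entries), and these do not reduce to one number. Compound 1 `CCC[C@]1(C(=O)N2CC[C@](c3ccc(C(F)(C(F)(F)F)C(F)(F)F)cc3)(S(=O)(=O)c3ccc(F)cc3)C2)CC[C@H](C(=O)O)CC1` adds nothing to the comparison, with its entry reading "not determined" (no result reported) here.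

Compound 4 `CCC1(C(=O)N2CC[C@](c3ccc(C(F)(C(F)(F)F)C(F)(F)F)cc3)(S(=O)(=O)c3ccc(F)cc3)C2)CCS(=O)(=O)CC1` has not yet been measured. It carries 4-ethyl-1,1-dioxothian-4-yl in place of the 4-(hydroxymethyl)cyclohexyl of compound 3, on a carbonyl carbon whose other neighbour is an amide-type nitrogen in a ring: 4-ethyl-1,1-dioxothian-4-yl in place of 4-(hydroxymethyl)cyclohexyl on a carbonyl carbon.

Among the compounds with values here, no measured pair isolates this change, so the expectation rests on the levels seen so far, with compound 3 at 75% and compound 2 at 100%; 95% (2 entries) in this assay. A small upward move is anticipated, one that would stay within the usual scatter of repeated measurements. The expected change is a number 9 percentage points higher from compound 3 to compound 4 (within the scatter) in this estimate. For compound 4 the estimated value is 84%, with an expected range from 62% to 100% in this read-out.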

Compound 4, percent of the compound remaining: 3%
Estimate against measurement, compound 4: 81 percentage points above; the measured number lies below the stated range.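

In this assay, putting 4-ethyl-1,1-dioxothian-4-yl in place of 4-(hydroxymethyl)cyclohexyl on the carbonyl carbon gives a number 72 percentage points lower from compound 3 to compound 4 (beyond the scatter). Going by these compounds alone, the earlier compounds offered only separate levels and no step that isolated a single place, so this is the first direct sign that the read-out depends strongly on the group at this position, with the shared core unchanged. The step is also far larger than the difference among the repeated entries available for one compound of the series, which lie close together: the several entries of compound 2 in this assay, 100%; 95% (2 entries)

The exchange alters several things at once, including the ring, the ethyl group and the loss of the hydroxymethyl group, and the compounds shown cannot say which of these accounts for the step, nor do they give any cause for it. Also open, as far as these compounds go, is how this assay would respond to a plain 4-ethylcyclohexyl group, which would keep the all-carbon ring, or to a 1,1-dioxothian-4-yl ring carrying a hydroxymethyl group, an amine or a carboxylic acid instead of the ethyl group.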